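Amino for Chloro on Two Benzyl Purines in MOLT-4 Cells

The compounds below may be only part of what the source reports. "The series", "measured", "known", "first", "only" and "open" are said of these compounds alone.

Compound 1 `ClCc1ccccc1Cn1cnc2c(Cl)nc(Cl)nc21`: 630 nM
Compound 2 `ClCc1cccc(Cn2cnc3c(Cl)nc(Cl)nc32)c1`: > 100000 nM, a limit of the assay
Compound 3 `Nc1nc(Cl)c2ncn(Cc3ccccc3CCl)c2n1`: > 100000 nM, a limit of the assay

In a functional assay on MOLT-4 cells (Homo sapiens) for cytotoxicity, read by sulforhodamine B assay, with a stated time of 48 h (on this read-out higher numbers stand for weaker inhibition of growth and lower numbers for stronger inhibition of growth), compound 1 gives 630 nM. For compound 2 the assay reports only a limit, > 100000 nM. For compound 3 the assay likewise reports only a limit, > 100000 nM. The change from compound 1 to compound 3 is amino in place of chloro on an aromatic carbon, and it produced an at least 150-fold higher number from compound 1 to compound 3 (2.20 log units; beyond the scatter). The difference between the cores of compound 1 and compound 2 is not broken down here. Compound 4 `Nc1nc(Cl)c2ncn(Cc3cccc(CCl)c3)c2n1` differs from compound 2 by amino in place of chloro on an aromatic carbon, the same change in the same place. Since compound 2 already sits at the limit of > 100000 nM in this assay, at which 2 of the 3 values shown sit, the same change cannot be seen to move it further within this assay. Compound 4 is therefore expected at about 200000 nM, most probably reported again only as a limit. The step expected from that estimate is a step that the limit leaves unreadable from compound 2 to compound 4.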

Compound 4, concentration for total growth inhibition: > 100000 nM
Compound 4: only a limit was reported (the forecaster's own chance of this, stated with the estimate: 90%); the middle value lies beyond the limit too.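

Compound 2 and compound 4 both give only a limit in this assay, so the step between them cannot be read: the limit of > 100000 nM in this assay, at which 3 of the 4 values shown sit.

The compounds shown leave open whether amino in place of chloro changes growth inhibition in compound 2 at all.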